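Sulfonyl substituent change from compound 2 to compound 3

The source may hold more compounds than are shown below. What is called first, only, known or untested is meant among the compounds shown, and "the series" means these compounds.

- compound 1 `N#Cc1cc2c(nc1N1CCC(F)(C(=O)NS(=O)(=O)Cc3ccc(Cl)cc3)CC1)COC2=O` gives 37200 nM in a functional assay (Platelet, plasma) for inhibition, with Homo sapiens as the target; on this read-out lower numbers stand for stronger inhibition and higher numbers for weaker inhibition
- compound 2 `N#Cc1cc2c(nc1N1CCC(C(=O)NS(=O)(=O)Cc3ccccc3F)CC1)COC2=O` gives 23700 nM in this assay

Among the compounds with values here, compound 2 stands within the scatter of compound 1, so these two values set no order between the compounds. Compound 3 `N#Cc1cc2c(nc1N1CCC(C(=O)NS(=O)(=O)C3(c4ccccc4)CC3)CC1)COC2=O` is the next case: 1-phenylcyclopropyl in place of 2-fluorobenzyl on a sulfonyl sulfur in short, 1-phenylcyclopropyl in place of 2-fluorobenzyl on a sulfonyl sulfur. Within the data shown here, no measured pair differs in this one place alone, so the data give no direct measure of the change. In this assay no step beyond the scatter is expected, and neither direction is favoured. The estimate starts from compound 2 at 23700 nM as its anchor, with a wide range. The expected change is a 1.2-fold lower number from compound 2 to compound 3 (0.07 log units; within the scatter) as an estimate. Compound 3 is expected at 20000 nM (estimated range 6000 nM to 60000 nM).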

Compound 3, half-maximal inhibitory concentration: 4100 nM
The estimate for compound 3 lay 4.9-fold (0.69 log units) above the measured number; the whole stated range lies above it.
By their numbers in this assay, from the lowest: compound 3; then compounds 2 and 1 (each within the scatter of the next).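

In this assay, within the data shown here, the substituent on the sulfonyl sulfur proves able to move the read-out: 1-phenylcyclopropyl in place of 2-fluorobenzyl gives a 5.8-fold lower number from compound 2 to compound 3 (0.76 log units; beyond the scatter) and is the only step so far that lies beyond the scatter. The change keeps the six-membered aromatic ring and the zero counts of hydrogen-bond donors and acceptors, while it adds a three-membered carbon ring and removes the fluorine. Nothing measured here accounts for this step.

The gain is not yet divided between the added three-membered ring and the lost fluorine, and a plain benzyl group or a 1-(2-fluorophenyl)cyclopropyl group would separate the two. Also open, from the compounds shown here alone, is how far the step extends to larger rings, such as 1-phenylcyclobutyl, on the same sulfonyl sulfur.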